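Swapping butyl for ethoxycarbonyl on the ring nitrogen

The source may hold more compounds than are shown below. What is called first, only, known or untested is meant among the compounds shown, and "the series" means these compounds.

Three compounds sharing one core, compound 1 `CN(C)C(=S)SC(=S)N1CCCCCC1`, compound 2 `CN1CCN(C(=S)SC(=S)N(C)C)CC1` and compound 3 `CCCCN1CCN(C(=S)SC(=S)N(C)C)CC1`, were tested in an ADME assay on HeLa cells (Homo sapiens) for cytotoxicity, read by MTT assay, with a stated time of 24 h; on this read-out higher numbers stand for weaker inhibition and lower numbers for stronger inhibition. For compound 1 the assay reports only a limit, > 5000000 nM. Among the measured compounds shown here, compound 2 gives 1220000 nM and compound 3 gives 4100000 nM, so compound 3 holds the highest of the two numbers; the single measured step, a 3.4-fold higher number from compound 2 to compound 3 (0.53 log units; beyond the scatter), is a modest rise from lengthening a chain. Compound 4 `CCOC(=O)N1CCN(C(=S)SC(=S)N(C)C)CC1` differs from compound 3 by ethoxycarbonyl in place of butyl on an amine nitrogen in a ring. For the measured compounds named here, no measured step exchanges a chain for a carbonyl-bearing group, so the one step measured offers no direct guide. The step from compound 3 to compound 4 is therefore expected to stay within the scatter, a 1.2-fold lower number from compound 3 to compound 4 (0.07 log units; within the scatter). Compound 4 is estimated at 3500000 nM, between 1200000 nM and 9000000 nM.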

Compound 4, half-maximal inhibitory concentration: 530000 nM
Compound 4: middle estimate off by 6.6-fold (0.82 log units), on the high side; the measured number lies below the stated range.
By their numbers in this assay, from the lowest: compound 4; then compound 2; then compound 3. At a limit, above all of these: compound 1.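

Ethoxycarbonyl on the amine nitrogen in a ring gives a 7.7-fold lower number from compound 3 to compound 4 (0.89 log units; beyond the scatter) and, set against methyl, a 2.3-fold lower number from compound 2 to compound 4 (0.36 log units; beyond the scatter) on the same nitrogen. So this position does not simply follow chain length, as the single earlier step from methyl to butyl might have suggested: a carbonyl-bearing group brings compound 4 to the lowest number of those measured. Nothing measured here tells what lies behind this drop.

Still open, going by these compounds, is whether the carbonyl or the ethyl part of the group matters. An acetyl group, a plain ethyl chain or a longer butoxycarbonyl on this nitrogen could separate the two.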